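Hydrazide series: cytotoxicity in mouse peritoneal macrophages

The source may hold more compounds than are shown below. What is called first, only, known or untested is meant among the compounds shown, and "the series" means these compounds.

Measured compounds:
- compound 1 `CCOC(=O)c1[nH]c2ccccc2c1/C=N\NC(=O)c1cc[n+]([O-])cc1`: 18 ug/mL
- compound 2 `O=C(N/N=C\c1c[nH]c2ccccc12)c1ccncc1`: 40 ug/mL
- compound 3 `NNC(=O)c1cc[n+]([O-])cc1`: 60 ug/mL

Three compounds have been run in an ADME assay on cells (Peritoneal macrophage cell, Mus musculus, strain C57BL/6) for cytotoxicity, read by LDH release; a higher number here means a weaker inhibitor, a lower number a stronger inhibitor. Compound 2 stands second highest of the three numbers. Its nearest neighbour is compound 3, whose value 60 ug/mL lies within the scatter of that of compound 2. Its furthest is compound 1, whose value 18 ug/mL is beyond the scatter, lower than that of compound 2. For the measured compounds named here, no pair among the measured compounds differs in one place only, so no single step can be read from them.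

Compound 4 `O=C(N/N=C\c1c[nH]c2ccccc12)c1cc[n+]([O-])cc1` is the next to go into this assay. It differs from compound 2 as follows: a group of 7 heavy atoms (5 carbon, 1 nitrogen, 1 oxygen; one six-membered aromatic ring with 1 hetero atom) in place of a group of 6 heavy atoms (5 carbon, 1 nitrogen; one six-membered aromatic ring with 1 hetero atom), on a carbonyl carbon The change touches the group on the carbonyl carbon of the hydrazide and leaves the rest of compound 2 untouched.

Going by the values given here, with no measured step of this kind available, the expectation rests on compound 2 alone. The step of a 1.1-fold lower number from compound 2 to compound 4 (0.06 log units; within the scatter) is estimated to be small, with no direction asserted beyond the scatter. Compound 4 is therefore expected to give about 35 ug/mL in this assay, with a likely range from 15 ug/mL to 80 ug/mL.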

Compound 4, half-maximal inhibitory concentration: 30 ug/mL
Estimate against measurement, compound 4: 1.2-fold (0.07 log units) above; the range from low to high includes it.
By their numbers in this assay, from the lowest: compounds 1, 4, 2 and 3 (each within the scatter of the next, the first and the last beyond it).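

In this assay, for the compounds shown here, the group of 7 heavy atoms can take the place of pyridin-4-yl on the carbonyl carbon with a step of a 1.3-fold lower number from compound 2 to compound 4 (0.12 log units; within the scatter), the first reading at this position, and it shows no separation between the two groups. The aromatic carbon carrying ethoxycarbonyl also becomes readable as a single change: hydrogen in its place gives a 1.7-fold higher number from compound 1 to compound 4 (0.22 log units; within the scatter), so this substituent is not separated from hydrogen on this core either. No measurement on hand offers an explanation for the size of either step.

Going by these compounds, whether an amine or a carboxylic acid on that aromatic carbon, or a phenyl group or longer chain on the carbonyl carbon, would give a step beyond the scatter remains open. Each change also rests on a single pair, leaving open whether it would read the same on another core.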